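A few compounds are considered here, and "the series" means these few. Any claim that something is new, unique, unknown or untested is made for them only; others in the source may bear on it.

Measured compounds:
- compound 1 `C=CCOC(=O)Nc1ccc([Se]C#N)cc1` gives 27000 nM in a functional assay on HTB-54 cells (Homo sapiens) for cytotoxicity, read by MTT assay, with a stated time of 72 h; on this read-out lower numbers stand for stronger inhibition of growth and higher numbers for weaker inhibition of growth
- compound 2 `N#C[Se]c1ccc(NC(=O)Oc2ccc(Cl)cc2)cc1` gives 13800 nM in this assay
- compound 3 `CCOC(=O)Nc1ccc([Se]C#N)cc1` gives 24900 nM in this assay

Compound 3 holds the second highest of the three numbers. Its nearest neighbour is compound 1, and its furthest is compound 2; both gaps are within the scatter, so no order among the three can be read from these values.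

The next compound, compound 4 `N#C[Se]c1ccc(NC(=O)Oc2ccccc2)cc1`, has not been measured. It differs from compound 3 by phenyl in place of ethyl on an oxygen next to a carbonyl group.

For the measured compounds named here, only one measured step touches this position: a 1.1-fold lower number from compound 1 to compound 3 (0.04 log units; within the scatter). That step swaps one small chain for another and changes nothing beyond the scatter. Going by the values given here, no measured step exchanges a chain for a ring at this oxygen. Compound 2 carries an aromatic ring at the same place, and its value sits within the scatter of compound 3; nothing more can be drawn from that pair.

The expectation for compound 4 in this assay is therefore a number close to compound 3, with at most a slight lowering, which the estimated step of a 1.5-fold lower number from compound 3 to compound 4 (0.17 log units; within the scatter) expresses. Compound 4 is estimated at 17000 nM, with a range from 8000 nM to 36000 nM.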

Compound 4, concentration for 50% growth inhibition: 26200 nM
Beside the measured number, compound 4's estimate is 1.5-fold (0.19 log units) below it, and the stated range covers the measured number.
By their numbers in this assay, from the lowest: compounds 2, 3, 4 and 1 (each within the scatter of the next).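

In this assay, the exchange of a chain for a ring at this oxygen can now be read directly: phenyl in place of ethyl gives a 1.1-fold higher number from compound 3 to compound 4 (0.02 log units; within the scatter), and phenyl in place of allyl gives a 1.0-fold lower number from compound 1 to compound 4 (0.01 log units; within the scatter). Neither step lies beyond the scatter, so these values do not separate the small chains from the six-membered aromatic ring at this place, although the group entering holds more heavy atoms than ethyl. For the compounds shown here, the ring's own substituent can also be read for the first time: hydrogen in place of chloro on an aromatic carbon gives a 1.9-fold higher number from compound 2 to compound 4 (0.28 log units; within the scatter), also within the scatter, and nothing available bears on the reason for any of these results.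

Open, as far as these compounds go, is whether any group on this oxygen can move the number beyond the scatter, for instance a longer chain, benzyl, or a chain ending in an amine or a carboxylic acid. Also open, from the compounds shown here alone, is whether a ring substituent other than chloro, such as methoxy or nitro, would separate from compound 4 in this assay.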